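The source may hold more compounds than are shown below. What is called first, only, known or untested is meant among the compounds shown, and "the series" means these compounds.

Compound 1, `Oc1ccc(-c2nc3cc(C(F)(F)F)ccc3[nH]2)cc1`, gives > 100000 nM in an ADME assay on BHK cells (Mesocricetus auratus) for cytotoxicity, read by MTT assay, with a stated time of 96 h; on this read-out lower numbers stand for higher toxicity in this test and higher numbers for lower toxicity in this test.
Compound 2, `O=C(CN1CCCC1)Nc1ccc(-c2nc3cc(Cl)c(Cl)cc3[nH]2)cc1`, gives 64000 nM in this assay.
Compound 3, `CCC(=O)Nc1ccc(-c2nc3ccccc3[nH]2)cc1`, gives >= 100000 nM in this assay.

Compound 1 stands at the upper edge of what this assay can report: its result is a limit of the test rather than a number, namely (the limit of > 100000 nM in this assay, at which 1 of the 3 values shown sits). Compound 3 also ends at a limit, (the limit of >= 100000 nM in this assay, at which 1 of the 3 values shown sits), so for two of the three compounds only a limit is known. Only compound 2 gives a number, and that number lies not far from the limits.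

Compound 4, `CC(=O)Nc1ccc(-c2nc3cc(C(F)(F)F)ccc3[nH]2)cc1`, keeps the core of compound 1 and differs from it in one place: acetamido in place of hydroxy on an aromatic carbon. Within the data shown here, no measured pair shows what such a change does in this assay. Compound 3 carries a related amide on the shared core and sits at a limit, which gives no sign that an amide lifts toxicity here. The step from compound 1 to compound 4 is therefore expected to be none beyond the scatter, a number no higher from compound 1 to compound 4 (the limit leaves the size open). Compound 4 is expected to give about 100000 nM, within 50000 nM to 200000 nM, and most likely again only a limit.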

Compound 4, half-maximal cytotoxic concentration: 53000 nM
Beside the measured number, compound 4's estimate is 1.9-fold (0.28 log units) above it; low and high end bracket the measured number.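

Among these compounds, this is the first pair in this assay that differs in one place, here on an aromatic carbon para to a large group: acetamido in place of hydroxy gives an at least 1.8-fold lower number from compound 1 to compound 4 (0.27 log units; that floor lies within the scatter). Compound 4 ends on a number rather than at the upper edge of the test, but the floor of this step lies within the scatter, so the pair does not establish that the change lowers the number. Going by these compounds, compound 1 ends at a limit, and the true size of the step therefore stays unknown: (the limit of > 100000 nM in this assay, at which 1 of the 4 values shown sits).

On these data alone, how far compound 1 lies beyond its limit remains open, so this step could be small or large. Also open, as far as these compounds go, is what an amine or a carboxylic acid would do on the same aromatic carbon of the shared core.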